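The source may report more compounds than this note shows. Statements on the series, on what has been measured and on what is new or still open speak of the compounds shown alone.

Among the compounds with values here, compound 2 `COc1ccc([C@@H]2C/C(=N\O)c3c(O)cc(OCc4cn(Cc5ccccc5F)nn4)cc3O2)cc1O` gives the lowest of the three numbers measured so far in a functional assay on RAW264.7 cells (Mus musculus) for inhibition, read by Griess assay, with stated times of 2 h and 24 h (on this read-out higher numbers stand for weaker inhibition and lower numbers for stronger inhibition), namely 5710 nM. Within the data shown here, compound 1 `COc1ccc([C@@H]2C/C(=N\O)c3c(O)cc(OCc4cn(Cc5ccccc5Cl)nn4)cc3O2)cc1O` gives 13400 nM, and the step of a 2.3-fold lower number from compound 1 to compound 2 (0.37 log units; beyond the scatter) is the only single-point change measured. Compound 3 `COc1ccc([C@@H]2CC(=O)c3c(O)cc(OCc4cn(CCCO)nn4)cc3O2)cc1O` gives 16700 nM; it differs from compound 2 in more than one place, so the two values simply stand side by side. Compound 4 `CCn1cc(COc2cc(O)c3c(c2)O[C@H](c2ccc(OC)c(O)c2)C/C3=N\O)nn1` differs from compound 2 by methyl in place of 2-fluorophenyl on a saturated chain carbon bound to an aromatic nitrogen. Among the measured compounds shown here, no measured step bears directly on this change, which is far larger than the fluoro-for-chloro swap. A weakening step is therefore expected, a 2.1-fold higher number from compound 2 to compound 4 (0.32 log units; beyond the scatter). Compound 4 is estimated at 12000 nM, with a range from 5000 nM to 30000 nM.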

Compound 4, half-maximal inhibitory concentration: 3140 nM
Compound 4: the middle estimate sits 3.8-fold (0.58 log units) above what was measured, outside the stated range (below it).
By their numbers in this assay, from the lowest: compounds 4 and 2 (each within the scatter of the next); then compounds 1 and 3 (each within the scatter of the next).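

In this assay, the aromatic ring on this saturated chain carbon bound to an aromatic nitrogen proves dispensable: methyl in place of 2-fluorophenyl gives a 1.8-fold lower number from compound 2 to compound 4 (0.26 log units; within the scatter) and so leaves the number unchanged within the scatter. Methyl in place of 2-chlorophenyl gives a 4.3-fold lower number from compound 1 to compound 4 (0.63 log units; beyond the scatter), so this small group also matches the better of the two halogen-bearing groups and goes beyond the weaker one. No supporting measurement explains this result. From the compounds shown here alone, whether an amine, a carboxylic acid or a longer chain in place of the methyl would keep the number there remains open.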